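The source may report more compounds than this note shows. Statements on the series, on what has been measured and on what is new or still open speak of the compounds shown alone.

Measured so far in a physicochemical assay for solubility; on this read-out lower numbers stand for lower solubility and higher numbers for higher solubility:
compound 1 `O=C(c1ccc(Cl)cc1)N1CCC(NS(=O)(=O)c2cc(S(=O)(=O)c3ccccc3)ccc2C(F)(F)F)CC1`, 3100 nM;
compound 2 `O=S(=O)(NC1CCN(S(=O)(=O)c2ccccc2)CC1)c1cc(S(=O)(=O)c2ccccc2)ccc1C(F)(F)F`, 25000 nM.

Compound 1 gives the lowest of the two numbers in this assay; the nearest is compound 2, reached by an 8.1-fold higher number from compound 1 to compound 2 (0.91 log units; beyond the scatter). Compound 3 `O=C(O)c1cccc(S(=O)(=O)N2CCC(NS(=O)(=O)c3cc(S(=O)(=O)c4ccccc4)ccc3C(F)(F)F)CC2)c1` is not yet measured. Its change from compound 1 is (3-carboxyphenyl)sulfonyl in place of (4-chlorophenyl)carbonyl on an amine nitrogen in a ring. Among the measured compounds shown here, the one measured step that bears on it is an 8.1-fold higher number from compound 1 to compound 2 (0.91 log units; beyond the scatter), likewise a sulfonyl in place of (4-chlorophenyl)carbonyl on the same amine nitrogen in a ring; no measured step isolates the carboxy group. Compound 3 is therefore expected to rise in this assay by a step of similar size or somewhat larger, a 13-fold higher number from compound 1 to compound 3 (1.11 log units; beyond the scatter). The estimate for compound 3 is 40000 nM, in the range 10000 nM to 160000 nM.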

Compound 3, solubility: 12500 nM
Compound 3: the middle estimate sits 3.2-fold (0.51 log units) above what was measured; measured number inside the range.
By their numbers in this assay, from the lowest: compound 1; then compounds 3 and 2 (each within the scatter of the next).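

In this assay the (3-carboxyphenyl)sulfonyl group on the amine nitrogen in a ring gives a 4.0-fold higher number from compound 1 to compound 3 (0.61 log units; beyond the scatter) and so a second sulfonyl replacement for (4-chlorophenyl)carbonyl reads on the same side as the phenylsulfonyl of compound 2. Carboxy in place of hydrogen on an aromatic carbon gives a 2.0-fold lower number from compound 2 to compound 3 (0.30 log units; within the scatter) and so separates compound 3 from compound 2 by no more than the scatter. Open, from the compounds shown here alone, is whether an amine in place of that carboxy reads alike in this assay and whether carboxy on the carbonyl-linked aryl group tracks the sulfonyl pair. No evidence at hand bears on these numbers.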